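The source may report more compounds than this note shows. Statements on the series, on what has been measured and on what is new or still open speak of the compounds shown alone.

For the measured compounds named here, compound 1 `Nc1sc2c(c1C(=O)c1cccc(Cl)c1)CCCC2` is one of three compounds so far examined in an assay with adenosine receptor A1 (Rattus norvegicus) as the target; on this read-out lower numbers stand for an effect already at smaller amounts and higher numbers for an effect only at larger amounts of compound. In this assay compound 1 gives 10500 nM. Compound 2 `Nc1sc2c(c1C(=O)c1ccc(Cl)c(Cl)c1)CCCC2` differs from it in a single place: chloro in place of hydrogen on an aromatic carbon In this assay compound 2 gives 6200 nM, so that a 1.7-fold lower number from compound 1 to compound 2 (0.23 log units; within the scatter). Compound 3 `Nc1sc2c(c1C(=O)c1ccc(Cl)cc1)CCN(Cc1ccccc1)C2` is built on a different core; how its core differs from the core of compound 1 is not broken down here. In this assay compound 3 gives 11300 nM, a number that lies within the scatter of the numbers for compound 1 and compound 2. Compound 4 `Nc1sc2c(c1C(=O)c1ccc(Cl)c(Cl)c1)CCN(Cc1ccccc1)C2` has not yet been measured. Going by the values given here, it differs from compound 3 in one place: chloro in place of hydrogen on an aromatic carbon This is the same kind of change as the one from compound 1 to compound 2, though the surroundings differ: in compound 4 the entering chloro is meta to a large group, whereas in compound 2 it is para to a large group. Because a 1.7-fold lower number from compound 1 to compound 2 (0.23 log units; within the scatter) stays within the scatter, the step of a 1.6-fold lower number from compound 3 to compound 4 (0.21 log units; within the scatter) is expected to be of similar modest size. Compound 4 is therefore estimated at 7000 nM in this assay, with a likely range from 2500 nM to 20000 nM.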

Compound 4, half-maximal effective concentration: 9200 nM
The estimate for compound 4 lay 1.3-fold (0.12 log units) below the measured number; the range from low to high includes it.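

Carried over to the other core, chloro in place of hydrogen on an aromatic carbon, here the change from 4-chlorophenyl to 3,4-dichlorophenyl, gives a 1.2-fold lower number from compound 3 to compound 4 (0.09 log units; within the scatter) in this assay. Set beside the earlier step, the change reads alike on the two cores: the same change on two cores in this assay, a 1.7-fold lower number (0.23 log units; within the scatter) from compound 1 to compound 2 and a 1.2-fold lower number (0.09 log units; within the scatter) from compound 3 to compound 4, 1.4-fold (0.14 log units) apart, within the scatter of two such steps. This shows that in both pairs the added chloro leaves the number within the scatter, but it does not show that the change has a real effect on either core, and two pairs cannot say how it would behave on a further core.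

The compounds shown leave open whether a group other than chloro at this place on the aromatic ring, such as a methoxy group, an amine or a carboxylic acid, would shift the number beyond the scatter. They also leave open whether the same change would read alike on a core carrying a longer chain in place of the groups seen so far.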